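The compounds below may be only part of what the source reports. "The series", "measured", "known", "first", "only" and "open" are said of these compounds alone.

Three compounds share one core and differ only in the group carried on one aromatic carbon. Compound 1 `Cc1nc2c3ccccc3ccc2c2nc3c(ccc4ccccc43)c(-c3cccc4ccccc34)c12` gives 111 ug/mL in a functional assay, read by spectrophotometry, with a stated time of 30 min; a higher number here means a weaker inhibitor, a lower number a stronger inhibitor. Compound 2 `Cc1nc2c3ccccc3ccc2c2nc3c(ccc4ccccc43)c(-c3ccccc3S)c12` gives 89 ug/mL in this assay, and compound 3 `Cc1nc2c3ccccc3ccc2c2nc3c(ccc4ccccc43)c(-c3ccc(O)cc3)c12` gives 86.4 ug/mL in this assay. Compound 3 has the lowest of the three numbers, but the steps of a 1.3-fold lower number from compound 1 to compound 3 (0.11 log units; within the scatter) and a 1.0-fold lower number from compound 2 to compound 3 (0.01 log units; within the scatter) are both within the scatter, as is a 1.2-fold lower number from compound 1 to compound 2 (0.10 log units; within the scatter); no exchange at this aromatic carbon has yet moved the number beyond the scatter.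

Compound 4 `Cc1ccc(-c2c3ccc4ccccc4c3nc3c2c(C)nc2c4ccccc4ccc32)cc1` differs from compound 3 by methyl in place of hydroxy on an aromatic carbon; cut one bond further out, the change reads 4-hydroxyphenyl to 4-methylphenyl. For the measured compounds named here, no measured step exchanges these two groups directly. Going by the values given here, the steps that bear on it are the two into compound 3, from compound 1 and from compound 2, both within the scatter despite larger exchanges of the ring. The step of a 1.1-fold higher number from compound 3 to compound 4 (0.03 log units; within the scatter) is therefore expected to stay within the scatter, with no direction favoured. The estimate for compound 4 in this assay is 92 ug/mL, within 50 ug/mL to 170 ug/mL.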

Compound 4, half-maximal inhibitory concentration: 123 ug/mL
The estimate for compound 4 lay 1.3-fold (0.13 log units) below the measured number; low and high end bracket the measured number.
By their numbers in this assay, from the lowest: compounds 3, 2, 1 and 4 (each within the scatter of the next).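

Hydroxy carries a hydrogen-bond donor and acceptor and methyl carries neither, yet this direct exchange on the phenyl ring gives a 1.4-fold higher number from compound 3 to compound 4 (0.15 log units; within the scatter) in this assay, so losing both counts leaves the number inside the scatter. The two larger exchanges also stay inside it, with a 1.4-fold higher number from compound 2 to compound 4 (0.14 log units; within the scatter) and a 1.1-fold higher number from compound 1 to compound 4 (0.04 log units; within the scatter), which extends the flat picture at this aromatic carbon to four groups and leaves no ranking among compounds 1, 2, 3 and 4. Nothing measured on these compounds offers an explanation for this flatness.

On these data alone, whether a carboxylic acid or an amine in place of the methyl of compound 4 would move the number beyond the scatter remains open. So does whether any change elsewhere on the shared core would do so.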